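This account rests on a few compounds, and the source may have more. Where it says the series, first, only, none or still open, it means among the compounds named here.

Three agonists of the same general design have been measured in a functional assay on CHO cells for agonist activity at Free fatty acid receptor 1 (Homo sapiens), read by FLIPR and calcium flux; a lower number here means that less compound is needed, a higher number that more compound is needed for the effect. Compound 1, `COc1cc(C)c(-c2cccc(COc3ccc4c(c3)C(O)CC4CC(=O)O)c2)c(C)c1`, gives 550 nM. Compound 2, `Cc1ccc(-c2cccc(COc3ccc(S(=O)(=O)CC(=O)O)cc3)c2)c(Cl)c1`, gives 36.3 nM. Compound 3, `Cc1nc(-c2cccc(F)c2)sc1COc1ccc(S(=O)(=O)CC(=O)O)cc1`, gives 275 nM. Among these three numbers compound 3 stands second highest; its nearest neighbour is compound 1, whose value lies within the scatter of compound 3, while compound 2 stands furthest away, with a number well below that of compound 3 and beyond the scatter.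

Compound 4, `Cc1cccc(-c2nc(C)c(COc3ccc(S(=O)(=O)CC(=O)O)cc3)s2)c1`, differs from compound 3 in one place only: methyl in place of fluoro on an aromatic carbon. In the terms of the wider fragment, a 3-fluorophenyl becomes a 3-methylphenyl on the thiazole side of the shared core. Going by the values given here, no pair of measured compounds shows this exchange, so the expectation for the step rests on the single value of compound 3 and on the modest size of the change. He expects the step from compound 3 to compound 4 in this assay, a 1.4-fold lower number from compound 3 to compound 4 (0.14 log units; within the scatter), to be small, most likely not beyond the scatter, with a slight lean toward a lower number. Compound 4 is therefore estimated at 200 nM, with a range from 70 nM to 600 nM.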

Compound 4, half-maximal effective concentration: 214 nM
The estimate for compound 4 lay 1.1-fold (0.03 log units) below the measured number; measured number inside the range.
By their numbers in this assay, from the lowest: compound 2; then compounds 4, 3 and 1 (each within the scatter of the next, the first and the last beyond it).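

In this assay, putting methyl in place of fluoro on this aromatic carbon, meta to a large group, gives a 1.3-fold lower number from compound 3 to compound 4 (0.11 log units; within the scatter), so the two groups cannot be told apart at this place in this read-out. Going by these compounds alone, this is the only step in the set between compounds that differ in one place, and it gives the first direct reading of a change on the 3-fluorophenyl; compounds 1, 2 and 3 could only be set side by side, with no single place isolated. The compounds shown offer no measured finding that would explain why the two groups read alike.

This single pair leaves open whether other groups at this place, such as a methoxy, a trifluoromethyl or an amine, would also stay within the scatter of compound 3, or would move the number beyond it. It also leaves open whether the same exchange of fluoro for methyl would read the same way on another core, such as that of compound 1, or at another carbon of the same ring.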